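This account rests on a few compounds, and the source may have more. Where it says the series, first, only, none or still open, it means among the compounds named here.

Within the data shown here, in a functional assay on KB cells (Homo sapiens) for inhibition, read by MTT assay, with a stated time of 24 h, tested at 10 ug/mL (a higher number here means more inhibition of growth at the concentration tested, a lower number less inhibition of growth), compound 1 (`CC(=O)SCCC(CCCCC(=O)O)SC(C)=O`) gives 8.88%, the only number available, while compound 2 (`O=C(CCCCC(S)CCS)Nc1cccc(Cl)c1`) is reported as "not active" (no number reported). Compound 3 (`CC(=O)SCCC(CCCCC(=O)Nc1ccc(Cl)cc1)SC(C)=O`) keeps the core of compound 1 but carries (4-chlorophenyl)amino in place of hydroxy on a carbonyl carbon. Among the measured compounds shown here, no measured step shows what this exchange does, so only a modest upward move in this assay is expected, possibly no larger than the scatter. The expected change is a number 6.1 percentage points higher from compound 1 to compound 3 (within the scatter). For compound 3 the estimated value is 15%, within an expected range of 3% to 40%.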

Compound 3, percent growth inhibition at one concentration: 18.1%
Compound 3: the middle estimate sits 3.1 percentage points below what was measured; the range from low to high includes it.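

In this assay, among these compounds, placing (4-chlorophenyl)amino in place of hydroxy on a carbonyl carbon gives a number 9.2 percentage points higher from compound 1 to compound 3 (within the scatter), the first measured step at this position. The carboxylic acid of compound 1 can therefore give way to this much larger group, with its six-membered aromatic ring, without a change beyond the usual scatter. No measurement shown here offers a reason for this step.

As far as these compounds go, it remains open whether a plain phenylamino group, without the chlorine, or a methyl ester on the same carbonyl carbon would move the growth inhibition beyond the scatter.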